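Swapping the Imidazole for Pyridine: A Solubility Outlook

This account rests on a few compounds, and the source may have more. Where it says the series, first, only, none or still open, it means among the compounds named here.

Among the compounds with values here, compound 1 `Cc1ccc(-c2c[nH]cn2)cc1NC(=O)c1ccc(OCc2ccccn2)cc1` is the only compound in this set with a numerical reading in a physicochemical assay for solubility, at pH 7.4; a lower number here means a less soluble compound, a higher number a more soluble compound; compound 1 gives 90000 nM. Compound 2 `Cc1ccc(-c2nccs2)cc1NC(=O)c1ccc(OCc2ccccn2)cc1` is its nearest measured neighbour. In this assay compound 2 reaches only a limit of the assay, < 1000 nM. Within the data shown here, the measured step of an at least 90-fold lower number from compound 1 to compound 2 (1.95 log units; beyond the scatter) is therefore the single piece of evidence available, and its true size is bounded by the limit of < 1000 nM in this assay, at which 1 of the 2 values shown sits. Compound 3 `Cc1ccc(-c2cccnc2)cc1NC(=O)c1ccc(OCc2ccccn2)cc1` differs from compound 1 by pyridin-3-yl in place of 1H-imidazol-4-yl on an aromatic carbon. Among the measured compounds shown here, as in the step to compound 2, the group that leaves carries the hydrogen-bond donor and the group that enters carries none, so the one measured step bears directly on this change, and a large downward step in this assay is expected for compound 3. The expected step of a 30-fold lower number from compound 1 to compound 3 (1.48 log units; beyond the scatter) is estimated to fall somewhat short of the change seen to compound 2, whose reading stopped at a limit. Compound 3 is accordingly expected near 3000 nM, within a range from 500 nM to 20000 nM, with a real chance that only a limit is reported.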

Compound 3, solubility: < 1000 nM
Compound 3 ended at the assay's limit; the forecaster's own chance of this, stated with the estimate: 35%; middle value at least 3.0-fold (0.47 log units) from the limit.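

In this assay, pyridin-3-yl in place of 1H-imidazol-4-yl on the aromatic carbon para to a methyl group gives an at least 90-fold lower number from compound 1 to compound 3 (1.95 log units; beyond the scatter), so a large downward step at this position is no longer tied to 1,3-thiazol-2-yl alone. The entering group here is a six-membered aromatic ring with 0 hydrogen-bond donors, and a large step now appears with this ring as well as with the thiazole of compound 2, so these readings do not set the two replacements apart. Compound 3 reaches only a limit of the assay, which leaves the step between compound 2 and compound 3 unreadable and the true size of both downward steps bounded rather than known: the limit of < 1000 nM in this assay, at which 2 of the 3 values shown sit.

Each of the two changes replaces a whole ring, so the compounds shown cannot tell whether the loss of the hydrogen-bond donor alone goes with the drop. From the compounds shown here alone, how a 1-methyl-1H-imidazol-4-yl group, or a pyridin-3-yl ring carrying an amine, would read against compound 1 at 90000 nM remains open.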